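The source may report more compounds than this note shows. Statements on the series, on what has been measured and on what is new or still open speak of the compounds shown alone.

Measured so far:
Compound 1 `Cc1ccc(N(CCN2CCC(OCC(=O)O)CC2)C(=O)c2cccc(C)c2)cc1`: 160 nM
Compound 2 `Cc1cccc(C(=O)N(CCN2CCC(OCC(=O)O)CC2)c2ccc(Cl)cc2)c1`: 310 nM

In a functional assay on a cell-free system (Platelet, plasma, Homo sapiens) for inhibition (on this read-out lower numbers stand for stronger inhibition and higher numbers for weaker inhibition), compound 1 gives 160 nM and compound 2 gives 310 nM, so the two stand within the scatter of each other. Compound 3 `COc1ccc(C(=O)N(CCN2CCC(OCC(=O)O)CC2)c2ccc(C)cc2)cc1OC` carries a new group on the core of compound 1: 3,4-dimethoxyphenyl in place of 3-methylphenyl on a carbonyl carbon. Within the data shown here, the only measured step, a 1.9-fold higher number from compound 1 to compound 2 (0.29 log units; within the scatter), is chloro in place of methyl on an aromatic carbon, so it leaves the group on the carbonyl carbon untouched and offers only weak guidance. The expected change is therefore none beyond the scatter, with an estimated step of a 1.4-fold higher number from compound 1 to compound 3 (0.14 log units; within the scatter). Compound 3 is estimated at 220 nM, with an expected range of 60 nM to 800 nM.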

Compound 3, half-maximal inhibitory concentration: > 3000 nM
Compound 3 was reported as a limit; the forecaster's own chance of this, stated with the estimate: 3%; middle value at least 13-fold (1.13 log units) from the limit.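

In this assay, among these compounds, the group on the carbonyl carbon proves far less forgiving than the earlier compounds suggested: 3,4-dimethoxyphenyl in place of 3-methylphenyl gives an at least 18-fold higher number from compound 1 to compound 3 (1.27 log units; beyond the scatter). By contrast, chloro in place of methyl on an aromatic carbon left compound 1 and compound 2 within the scatter of each other. The result for compound 3 is a limit, not a number: the limit of > 3000 nM in this assay, at which 1 of the 3 values shown sits.

The compounds shown leave open whether a single methoxy group or an unsubstituted phenyl on the carbonyl carbon would stay close to compound 1 or fall towards compound 3.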